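The source may report more compounds than this note shows. Statements on the series, on what has been measured and on what is new or still open speak of the compounds shown alone.

Compound 1, `COc1ccc2[nH]c(C(=O)N3CC(=O)N(Cc4ccccc4)[C@@H](CCc4ccccc4)C3)cc2c1`: in an ADME assay on Vero cells (Chlorocebus sabaeus) for cytotoxicity, with a stated time of 7 days (on this read-out lower numbers stand for higher toxicity in this test and higher numbers for lower toxicity in this test), compound 1 gives > 30000 nM, which is a limit of the assay and not a number.
Compound 2, `COc1ccc2[nH]c(C(=O)N3CC(=O)N(Cc4ccccc4)[C@@H](COCc4ccccc4)C3)cc2c1`: in this assay compound 2 gives > 30000 nM, again a limit.
Compound 3, `COc1ccc2[nH]c(C(=O)N3CC(=O)N(Cc4ccccc4)[C@@H](CN4CCC(C)CC4)C3)cc2c1`: in this assay compound 3 gives > 30000 nM, also a limit.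

All three values sit at the same limit (the limit of > 30000 nM in this assay, at which 3 of the 3 values shown sit), so compound 3 cannot be placed above or below compound 1 or compound 2 on these numbers. The steps that lead to it, a step that the two limits leave unreadable from compound 1 to compound 3 and a step that the two limits leave unreadable from compound 2 to compound 3, are unreadable for the same reason, and so is a step that the two limits leave unreadable from compound 1 to compound 2.

Compound 4, `COc1ccc2[nH]c(C(=O)N3CC(=O)N(Cc4ccccc4)[C@@H](N4CCc5ccccc54)C3)cc2c1`, differs from compound 3 in one place: 2,3-dihydro-1H-indol-1-yl in place of (4-methylpiperidin-1-yl)methyl on a saturated ring carbon. Going by the values given here, no measured step involving the shared core gives a readable size, so the only guide is that every change seen so far has left the value at the limit. Compound 4 is therefore expected to stay at the limit as well, an estimate of 30000 nM with a range from 15000 nM to 60000 nM. The step this estimate means, a number no higher from compound 3 to compound 4 (the limit leaves the size open), is expected to be none beyond the scatter.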

Compound 4, half-maximal cytotoxic concentration: > 100000 nM
Compound 4: only a limit was reported; the forecaster's own chance of this, stated with the estimate: 85%; at least 3.3-fold (0.52 log units) between middle value and limit.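

Going by these compounds alone, compound 1, compound 2, compound 3 and compound 4 are all reported only as limits, so in this assay no step between them can be read. The compounds shown leave open whether any group on the saturated ring carbon gives a measurable cytotoxic concentration.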